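A few compounds are considered here, and "the series" means these few. Any claim that something is new, unique, unknown or untested is made for them only; others in the source may bear on it.

Compound 1 `Cc1ccc(Cn2c(Cl)nc3cc(Cl)c(Cl)cc32)cc1`, compound 2 `FC(F)(F)c1cc(Cn2c(Cl)nc3cc(Cl)c(Cl)cc32)cc(C(F)(F)F)c1` and compound 3 `Cc1ccc(Cn2c(Br)nc3cc(Cl)c(Cl)cc32)cc1` share a halogenated core and were tested in a functional assay on KB cells (Homo sapiens) for inhibition; on this read-out higher numbers stand for weaker inhibition and lower numbers for stronger inhibition. In this assay compound 1 gives > 100000 nM, which is a limit of the assay rather than a number. Compound 2 gives > 100000 nM in this assay, again only a limit. Compound 3 gives > 100000 nM in this assay, also a limit. How the core of compound 2 differs from the core of compound 1 is not broken down here. Compound 3 differs from compound 1 by bromo in place of chloro on an aromatic carbon, and the step that the two limits leave unreadable from compound 1 to compound 3 cannot be sized because of the limit of > 100000 nM in this assay, at which 3 of the 3 values shown sit. Compound 4 `FC(F)(F)c1cc(Cn2c(Br)nc3cc(Cl)c(Cl)cc32)cc(C(F)(F)F)c1`, not yet measured, differs from compound 2 by bromo in place of chloro on an aromatic carbon. This is the same kind of change, although the surroundings are described differently: next to the ring atom that bears a group of 8 heavy atoms in one case, next to the ring atom that bears a large group in the other. The step that the limit leaves unreadable from compound 2 to compound 4 is expected to be small, because the limit of > 100000 nM in this assay, at which 3 of the 3 values shown sit, gives no sign that the exchange of halogen moves anything. Compound 4 is therefore estimated at 200000 nM in this assay, most likely reported only as a limit, within 50000 nM to 1000000 nM.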

Compound 4, half-maximal inhibitory concentration: 70000 nM
Compound 4: the middle estimate sits 2.9-fold (0.46 log units) above what was measured, within the range that was stated.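

In this assay, bromo in place of chloro on an aromatic carbon gives an at least 1.4-fold lower number from compound 2 to compound 4 (0.15 log units; that floor lies within the scatter). That figure is only a floor, so the data do not establish that the exchange strengthens inhibition on the core of compound 2. Compound 4 gives 70000 nM, a measured number. The same exchange on the core of compound 1 cannot be read, so nothing shows whether the change carries from one core to the other or behaves differently on each, because both ends of that step are limits: the limit of > 100000 nM in this assay, at which 3 of the 4 values shown sit.

Still open, as far as these compounds go, is whether any other group on this carbon, between two ring nitrogen atoms, would give a number clearly away from the limit. An amine or a carboxylic acid in that place could give a clearly lower number in this assay or none at all, and the compounds shown do not settle which.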